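Cyano in place of vinyl: working notes on the series

This account rests on a few compounds, and the source may have more. Where it says the series, first, only, none or still open, it means among the compounds named here.

Measured in a functional assay on MDBK cells (Bos taurus) for cytotoxicity; a lower number here means that less compound is tolerated, a higher number that more compound is tolerated:
compound 1 `CO/N=C(\C#N)C(=O)NCC1=NOC(C(C)(C)C)C1` gives > 100 ug/mL
compound 2 `CCO/N=C(\C#N)C(=O)NCC1=NOC(C(C)(C)C)C1` gives > 100 ug/mL
compound 3 `C=CCO/N=C(\C#N)C(=O)NCC1=NOC(C(C)(C)C)C1` gives > 100 ug/mL

Compound 3 gives > 100 ug/mL as a limit of the assay, not a number. The two other measured compounds share that limit (the limit of > 100 ug/mL in this assay, at which 3 of the 3 values shown sit). Compound 4 `CC(C)(C)C1CC(CNC(=O)/C(C#N)=N/OCC#N)=NO1` differs from compound 3 as counted here (cyano in place of vinyl on a saturated chain carbon bound to an oxygen on an unsaturated carbon): cyano in place of vinyl on a saturated chain carbon bound to an oxygen on an unsaturated carbon. Three measured changes at that place bear on it, namely a step that the two limits leave unreadable from compound 1 to compound 2 and a step that the two limits leave unreadable from compound 1 to compound 3 and also a step that the two limits leave unreadable from compound 2 to compound 3 and none of them has a readable size. No size or direction can be carried over from them. All three compounds remain at the limit, so no step beyond the scatter is expected in this assay for this change. The estimated step is a number no higher from compound 3 to compound 4 (the limit leaves the size open) with no direction expected. For compound 4 the estimated value is 100 ug/mL with an expected range from 40 ug/mL to 200 ug/mL and another limit reading is the likeliest outcome.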

Compound 4, half-maximal cytotoxic concentration: > 100 ug/mL
Compound 4: a limit, no number; the forecaster's own chance of this, stated with the estimate: 80%; the middle value lies on the limit itself.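

In this assay compound 4 gives > 100 ug/mL, a limit of the assay and not a number. No step from compound 1, compound 2 or compound 3 to compound 4 can be read: the limit of > 100 ug/mL in this assay, at which 4 of the 4 values shown sit.

The compounds shown leave open where the half-maximal cytotoxic concentration of any of them actually lies, and whether cyano in place of vinyl changes it at all.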